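Compound 3 to compound 4: pyrrolidin-1-yl for dimethylamino

The compounds below may be only part of what the source reports. "The series", "measured", "known", "first", "only" and "open" are said of these compounds alone.

Compound 1 `CC[C@H](C)[C@@H]1C(=O)N[C@H](C2Cc3ccccc3C2)C(=O)N1[C@@H](C(=O)N1CCOCC1)c1cnc(C)cc1C`: 1110 ng.h/mL
Compound 2 `CCC(CC)[C@@H]1C(=O)N[C@H](C2Cc3ccccc3C2)C(=O)N1[C@@H](C(=O)N1CCOCC1)c1ccc(C)nc1`: 1380 ng.h/mL
Compound 3 `Cc1ccc([C@H](C(=O)N(C)C)N2C(=O)[C@@H](C3Cc4ccccc4C3)NC(=O)[C@H]2CC(C)C)cn1`: 2680 ng.h/mL

These three compounds were measured in an ADME assay on the whole organism (plasma) for pharmacokinetics, with Rattus norvegicus as the target, at a dose of 5 mg/kg by the oral route; on this read-out higher numbers stand for higher exposure at the dose given and lower numbers for lower exposure. Compound 3 lies beyond the usual scatter above compound 1, and within the scatter of compound 2. Compound 4 `Cc1ccc([C@H](C(=O)N2CCCC2)N2C(=O)[C@@H](C3Cc4ccccc4C3)NC(=O)[C@H]2CC(C)C)cn1` has pyrrolidin-1-yl in place of dimethylamino on a carbonyl carbon. Among the measured compounds shown here, no measured pair differs in one place, so the data show nothing directly about this change. The expectation therefore starts from compound 3 at 2680 ng.h/mL, with no step beyond the scatter and only a slight lean downward. The estimated change is a 1.2-fold lower number from compound 3 to compound 4 (0.09 log units; within the scatter). Compound 4 is expected at 2200 ng.h/mL, with an estimated range of 800 ng.h/mL to 5500 ng.h/mL.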

Compound 4, area under the concentration-time curve: 920 ng.h/mL
For compound 4 the middle estimate is 2.4-fold (0.38 log units) above the measured one; the measured number falls inside the stated range.
By their numbers in this assay, from the lowest: compounds 4, 1, 2 and 3 (each within the scatter of the next, the first and the last beyond it).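

Among the compounds shown here, the pair gives the first direct reading at this position: in this assay, pyrrolidin-1-yl in place of dimethylamino on a carbonyl carbon gives a 2.9-fold lower number from compound 3 to compound 4 (0.46 log units; beyond the scatter). Exposure is therefore sensitive to this amide group, and tying the two carbons of dimethylamino into a five-membered ring with two further carbons does not preserve it. Nothing available explains the step.

The compounds shown leave open how piperidin-1-yl or azetidin-1-yl would fare on the same carbonyl carbon. This single pair also cannot show whether the step carries over to other substituents on the shared core.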